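A few compounds are considered here, and "the series" means these few. Any claim that something is new, unique, unknown or untested is made for them only; others in the source may bear on it.

In a functional assay on Bel-7402 cells (Homo sapiens) for cytotoxicity, read by MTT assay, with a stated time of 72 h (a higher number here means a weaker inhibitor, a lower number a stronger inhibitor), three compounds on a shared core have been measured: compound 1 `C=C1C(=O)[C@@]23C(=O)OC[C@]4(C(=O)CCC(C)(C)[C@H]4C=O)[C@@H]2CC[C@@H]1[C@H]3O` gives 5030 nM, compound 2 `C=C1C(=O)[C@@]23C(=O)OC[C@]4([C@@H](OC(C)=O)CCC(C)(C)[C@H]4C=O)[C@@H]2CC[C@@H]1[C@H]3O` gives 75400 nM, and compound 3 `C=C1C(=O)[C@@]23C(=O)OC[C@]4(C(=O)CCC(C)(C)[C@H]4C=O)[C@@H]2CC[C@@H]1[C@H]3OC(C)=O` gives 1730 nM, the lowest of the three. Compound 4 `C=C1C(=O)[C@@]23C(=O)OC[C@]4(C(=O)CCC(C)(C)[C@H]4C=O)[C@@H]2CC[C@@H]1[C@H]3OC(=O)CC` differs from compound 3 by methyl in place of hydrogen on a saturated chain carbon bound to a carbonyl carbon, with methyl in place of hydrogen on a saturated chain carbon bound to a carbonyl carbon, which turns acetoxy to propanoyloxy. Among the measured compounds shown here, one measured step bears on this change: a 2.9-fold lower number from compound 1 to compound 3 (0.46 log units; beyond the scatter), where acetyl took the place of hydrogen. For the measured compounds named here, that step is modest, and no measured compound shows the effect of lengthening the acyl chain. A change beyond the scatter is therefore not expected in this assay. The expected step is a 1.1-fold lower number from compound 3 to compound 4 (0.03 log units; within the scatter). The estimate for compound 4 is 1600 nM, with an expected range from 700 nM to 3800 nM.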

Compound 4, half-maximal inhibitory concentration: 1650 nM
Compound 4: middle estimate off by 1.0-fold (0.01 log units), on the low side, and the stated range covers the measured number.
By their numbers in this assay, from the lowest: compounds 4 and 3 (each within the scatter of the next); then compound 1; then compound 2.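

In this assay, among the compounds shown here, the change from acetoxy to propanoyloxy gives a 1.0-fold lower number from compound 3 to compound 4 (0.02 log units; within the scatter) and so leaves the number unmoved, something the earlier compounds could not show. The gain seen on acylating this oxygen survives the added methyl, with a 3.0-fold lower number from compound 1 to compound 4 (0.48 log units; beyond the scatter) against the free hydroxyl form. No measurement offered here accounts for this result.

Still open, as far as these compounds go, is whether a longer chain on the acyl group, such as butanoyl, or a benzoyl group at this oxygen would shift the number beyond the scatter. An acyl group carrying an amine is equally untested among the compounds shown.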